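Removing a methoxy from the benzylamine of compound 1

The source may report more compounds than this note shows. Statements on the series, on what has been measured and on what is new or still open speak of the compounds shown alone.

Measured compounds:
compound 1 `COc1ccc(CNc2nc3cc(N)cc(N)c3nc2-c2ccccc2)cc1OC`: 17000 nM
compound 2 `CCOC(=O)[C@H](CCC(=O)O)NC(=O)c1ccc(Sc2nc3cc(N)cc(N)c3nc2-c2ccccc2)cc1`: 14500 nM
compound 3 `COc1cc(CNc2nc3cc(N)cc(N)c3nc2-c2ccccc2)cc(OC)c1OC`: 1740 nM

In a functional assay on U-251 cells (Homo sapiens) for inhibition, read by sulforhodamine B assay, with a stated time of 48 h (on this read-out higher numbers stand for weaker inhibition of growth and lower numbers for stronger inhibition of growth), compound 1 stands highest of the three, with compound 2 nearest and compound 3 furthest; the gap to compound 2 is within the scatter, the gap to compound 3 is not. Compound 4 `COc1ccc(CNc2nc3cc(N)cc(N)c3nc2-c2ccccc2)cc1` differs from compound 1 by hydrogen in place of methoxy on an aromatic carbon. Among the measured compounds shown here, the one measured step that bears on it runs the other way: adding a methoxy gave a 9.8-fold lower number from compound 1 to compound 3 (0.99 log units; beyond the scatter), a modest step beyond the scatter. Taking a methoxy away is therefore expected to move this assay in the opposite direction, towards a higher number, though with only one relevant step the size is uncertain and the step could fall within the scatter. For compound 4 the expected step is a 1.5-fold higher number from compound 1 to compound 4 (0.17 log units; within the scatter). Compound 4 is expected to give 25000 nM, with a range of 8000 nM to 80000 nM.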

Compound 4, concentration for 50% growth inhibition: 13500 nM
Compound 4: middle estimate off by 1.9-fold (0.27 log units), on the high side; the measured number falls inside the stated range.
By their numbers in this assay, from the lowest: compound 3; then compounds 4, 2 and 1 (each within the scatter of the next).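

In this assay, the change from 3,4-dimethoxyphenyl to 4-methoxyphenyl gives a 1.3-fold lower number from compound 1 to compound 4 (0.10 log units; within the scatter), so this methoxy, ortho to a methoxy group and meta to a large group, can be taken away without a shift beyond the scatter. The two steps on this ring are therefore not mirror images: adding a methoxy gave a 9.8-fold lower number from compound 1 to compound 3 (0.99 log units; beyond the scatter), whereas removing one leaves the number where it was within the scatter. Nothing measured here accounts for that difference between the two steps.

Open, from the compounds shown here alone, is whether a hydroxyl, a fluorine or an amine at this place would move the number beyond the scatter. Also open, going by these compounds, is whether the step to compound 3 depends on the added methoxy alone or on the full set of methoxy groups it carries.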